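Swapping a Quinoline for a Pyrazole on an Inactive Amide

The source may report more compounds than this note shows. Statements on the series, on what has been measured and on what is new or still open speak of the compounds shown alone.

Compound 2 `CCCn1c(NC(=O)c2ccc3ccccc3n2)nc2cc(C(N)=O)cc(OC)c21` carries a quinolin-2-yl group on the carbonyl carbon of its amide. In an assay for activation of interferon regulatory factor 3 (Homo sapiens), read by a luciferase reporter, with a stated time of 20 h (on this read-out lower numbers stand for an effect already at smaller amounts and higher numbers for an effect only at larger amounts of compound), compound 2 gives > 100000 nM, which is a limit of the assay rather than a measured number. Compound 1 `CCn1nc(C)cc1C(=O)Nc1nc2cc(C(N)=O)cc(OC)c2n1CCCNC(=O)OCc1ccccc1` is a relative with a different amide group and a longer side chain on the shared core. In this assay compound 1 gives > 100000 nM, again a limit. The two values shown therefore both sit at the limit of > 100000 nM in this assay, at which 2 of the 2 values shown sit. Compound 3 `CCCn1c(NC(=O)c2ccnn2C)nc2cc(C(N)=O)cc(OC)c21` is not yet measured and differs from compound 2 by 1-methyl-1H-pyrazol-5-yl in place of quinolin-2-yl on a carbonyl carbon. Since compound 1 also carries a pyrazole-type amide and sits at the same limit, no step beyond the usual scatter is expected here. The expected step is a number no higher from compound 2 to compound 3 (the limit leaves the size open). Compound 3 is expected to give about 100000 nM, most probably again as a limit, within a range from 30000 nM to 300000 nM.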

Compound 3, half-maximal effective concentration: > 100000 nM
Compound 3 ended at the assay's limit; the forecaster's own chance of this, stated with the estimate: 85%; the middle value sits exactly at the limit.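

No step can be read from compound 2 to compound 3, since both stop at a limit in this assay: the limit of > 100000 nM in this assay, at which 3 of the 3 values shown sit.

The compounds shown leave open whether quinolin-2-yl or 1-methyl-1H-pyrazol-5-yl on the carbonyl carbon matters at all, and what on the shared core would bring a measurable value.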